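A few compounds are considered here, and "the series" means these few. Any claim that something is new, unique, unknown or untested is made for them only; others in the source may bear on it.

Going by the values given here, compound 1 `Cn1nc(-c2nnc(SCCOc3ccccc3F)o2)cc1-c1ccc(C(F)(F)F)cc1` gives 23100 nM in a functional assay on MCF7 cells (Homo sapiens) for cytotoxicity, read by MTT assay, with a stated time of 24 h (on this read-out lower numbers stand for stronger inhibition and higher numbers for weaker inhibition), and is the only plain number among the two values shown. Compound 2 `Cn1nc(-c2nnc(SCc3cccc([N+](=O)[O-])c3)o2)cc1-c1ccc(C(F)(F)F)cc1` sits at > 100000 nM in this assay, which is a limit and not a number (the limit of > 100000 nM in this assay, at which 1 of the 2 values shown sits). The step of an at least 4.3-fold higher number from compound 1 to compound 2 (0.63 log units; beyond the scatter) is therefore at least modest and beyond the scatter. Compound 3 `Cn1nc(-c2nnc(SCc3ccc(Cl)cc3F)o2)cc1-c1ccc(C(F)(F)F)cc1` differs from compound 1 by 4-chloro-2-fluorophenyl in place of (2-fluorophenoxy)methyl on a saturated chain carbon bound to a sulfur. Among the compounds with values here, the one measured step bearing on this, also putting an aryl directly on that chain carbon, moved the number upward. For compound 3 the expected step is a 1.9-fold higher number from compound 1 to compound 3 (0.29 log units; within the scatter), toward a higher number. Compound 3 is thus estimated at 45000 nM, with a range of 15000 nM to 120000 nM.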

Compound 3, half-maximal inhibitory concentration: 18200 nM
Compound 3: the middle estimate sits 2.5-fold (0.39 log units) above what was measured, and the stated range covers the measured number.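

In this assay, the step of a 1.3-fold lower number from compound 1 to compound 3 (0.10 log units; within the scatter) shows that an aryl directly on the chain carbon bound to a sulfur need not carry the loss seen with compound 2. With that attachment kept, the aryl substitution itself separates the two compounds, with the step of an at least 5.4-fold lower number from compound 2 to compound 3 (0.73 log units; beyond the scatter). The entry for compound 2 is a limit and not a number: the limit of > 100000 nM in this assay, at which 1 of the 3 values shown sits.

The compounds shown leave open whether the chlorine or the fluorine of 4-chloro-2-fluorophenyl matters here. They also leave open how an amine, a carboxylic acid or a longer chain at this place would read out.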